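Changing the Aryl Group: Chlorophenyl to Trifluoromethylphenyl

The source may hold more compounds than are shown below. What is called first, only, known or untested is meant among the compounds shown, and "the series" means these compounds.

Compounds measured so far:
- Compound 1 `CCOC(=O)C1=Cc2ccccc2OC1(OCc1cc(-c2ccc(F)cc2F)no1)C(F)(F)F`: > 150000 nM
- Compound 2 `CCOC(=O)C1=Cc2ccccc2OC1(OCc1cc(-c2ccc(C)cc2)no1)C(F)(F)F`: > 150000 nM
- Compound 3 `CCOC(=O)C1=Cc2ccccc2OC1(OCc1cc(-c2ccc(Cl)cc2)no1)C(F)(F)F`: 12300 nM

In a functional assay on HeLa cells (Homo sapiens) for inhibition, read by MTT assay, with a stated time of 24 h (on this read-out higher numbers stand for weaker inhibition and lower numbers for stronger inhibition), compound 1 gives > 150000 nM, which is a limit of the assay and not a number. Compound 2 likewise gives > 150000 nM, again a limit. Among the compounds with values here, compound 3 gives 12300 nM, the only actual number among the three. Between the two limits the step that the two limits leave unreadable from compound 1 to compound 2 cannot be read. The two steps that end at compound 3 are readable: an at least 12-fold lower number from compound 1 to compound 3 (1.08 log units; beyond the scatter) and an at least 12-fold lower number from compound 2 to compound 3 (1.08 log units; beyond the scatter). So compound 3 stands alone as the one compound with a measured number, and the group attached to the five-membered ring clearly matters.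

Compound 4 `CCOC(=O)C1=Cc2ccccc2OC1(OCc1cc(-c2cccc(C(F)(F)F)c2)no1)C(F)(F)F` carries the change (3-(trifluoromethyl)phenyl in place of 4-chlorophenyl on an aromatic carbon). Within the data shown here, no measured step involves a trifluoromethyl group, so the three steps above bear on this change only indirectly: they show that swapping this aryl group can move the number by a large amount, and that two of the three compounds sit at the limit (the limit of > 150000 nM in this assay, at which 2 of the 3 values shown sit). A weaker result than compound 3 is therefore expected, on the order of a 3.3-fold higher number from compound 3 to compound 4 (0.51 log units; beyond the scatter). For compound 4 the estimate is 40000 nM, with a range from 8000 nM to 150000 nM.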

Compound 4, half-maximal inhibitory concentration: 21400 nM
Estimate against measurement, compound 4: 1.9-fold (0.27 log units) above, and the stated range covers the measured number.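

In this assay, putting 3-(trifluoromethyl)phenyl in place of 4-chlorophenyl gives a 1.7-fold higher number from compound 3 to compound 4 (0.24 log units; within the scatter), so these two aryl groups cannot be told apart on this read-out. A measurable number at this position, on the aromatic carbon next to the ring nitrogen of the five-membered ring, therefore does not depend on 4-chlorophenyl alone. The 3-(trifluoromethyl)phenyl group also stands clearly apart from the other two aryl groups, with an at least 7.0-fold lower number from compound 2 to compound 4 (0.84 log units; beyond the scatter) against 4-methylphenyl and an at least 7.0-fold lower number from compound 1 to compound 4 (0.84 log units; beyond the scatter) against 2,4-difluorophenyl, and both sizes are minimum sizes, not exact ones, as they start from a limit of the assay: the limit of > 150000 nM in this assay, at which 2 of the 4 values shown sit.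

The compounds shown leave open whether the kind of group on the phenyl ring or its place on that ring matters more, and 3-chlorophenyl and 4-(trifluoromethyl)phenyl would separate the two, as each would differ from a compound here in only one of these respects. They also leave open what a plain phenyl, or a phenyl carrying an amine or a carboxylic acid, would give at this position.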